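Working notes: removing one methoxy from compound 1

This account rests on a few compounds, and the source may have more. Where it says the series, first, only, none or still open, it means among the compounds named here.

Compound 1 `COc1cc(NC(=O)/C=C/c2ccccc2C(F)(F)F)cc(OC)c1OC`: > 200000 nM (a limit)
Compound 2 `O=C(/C=C/c1ccccc1C(F)(F)F)Nc1ccc(F)c(Cl)c1`: > 200000 nM (a limit)

Compound 1 reports no number in an ADME assay on HBZY-1 cells (Rattus norvegicus) for cytotoxicity, read by MTT assay, with a stated time of 2 h (on this read-out higher numbers stand for weaker inhibition and lower numbers for stronger inhibition), and stands at the limit of > 200000 nM in this assay, at which 2 of the 2 values shown sit (shared by both measured compounds). Compound 3 `COc1ccc(NC(=O)/C=C/c2ccccc2C(F)(F)F)cc1OC` is not yet measured. Its change from compound 1 is hydrogen in place of methoxy on an aromatic carbon. Among the measured compounds shown here, no measured step exists for this change, so none beyond the scatter is expected in this assay on the strength of the shared limit. The estimated a number no higher from compound 1 to compound 3 (the limit leaves the size open) is correspondingly small. Compound 3 is expected at 200000 nM within an estimated range of 100000 nM to 400000 nM and may well report only a limit.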

Compound 3, half-maximal inhibitory concentration: > 200000 nM
Compound 3 gave a limit, no number (the forecaster's own chance of this, stated with the estimate: 85%); the middle value lies on the limit itself.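

No step can be read from compound 1 to compound 3, as each reports only a limit: the limit of > 200000 nM in this assay, at which 3 of the 3 values shown sit.

In this assay the compounds shown leave open the size of any effect of hydrogen in place of methoxy, and whether any compound in the series gives a number.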